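Ethyl for methyl on two differently joined cores

The compounds below may be only part of what the source reports. "The series", "measured", "known", "first", "only" and "open" are said of these compounds alone.

Measured in an assay on isolated protein for inhibition of Fatty-acid amide hydrolase 1 (Homo sapiens), read by fluorescence, with a stated time of 30 min; on this read-out higher numbers stand for weaker inhibition and lower numbers for stronger inhibition:
compound 1 `CCOC(=O)c1cc(-c2cccc(OC(=O)NC3CCCCC3)c2)n(C)n1` gives 303 nM
compound 2 `CCOC(=O)c1cc(-c2cccc(OC(=O)NC3CCCCC3)c2)n(CC)n1` gives 101 nM
compound 3 `CCOC(=O)c1cc(-c2cccc(OC(=O)NC3CCCCC3)c2)nn1C` gives 227 nM

Compound 1 and compound 3 are built from the same atoms joined differently; the difference between the two cores is not broken down here. Their values in this assay lie within the scatter of each other. Within the data shown here, the one measured step, a 3.0-fold lower number from compound 1 to compound 2 (0.48 log units; beyond the scatter), comes from methyl in place of hydrogen on a saturated chain carbon bound to an aromatic nitrogen. Compound 4 `CCOC(=O)c1cc(-c2cccc(OC(=O)NC3CCCCC3)c2)nn1CC` carries the same change made on compound 3, (methyl in place of hydrogen on a saturated chain carbon bound to an aromatic nitrogen), with the place described in identical terms for both pairs. This is a single precedent, so the expectation for compound 4 rests on compound 1 and compound 2 alone: a step of about a 2.7-fold lower number from compound 3 to compound 4 (0.43 log units; beyond the scatter) is expected, drawn from a 3.0-fold lower number from compound 1 to compound 2 (0.48 log units; beyond the scatter) and widened for the uncertainty of one example. Compound 4 is estimated at 85 nM, between 35 nM and 210 nM.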

Compound 4, half-maximal inhibitory concentration: 507 nM
Compound 4: the middle estimate sits 6.0-fold (0.78 log units) below what was measured, and the stated range ends below it.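

In this assay, the change from methyl to ethyl gives a 2.2-fold higher number from compound 3 to compound 4 (0.35 log units; beyond the scatter), and it does not carry over between the two cores: the same change on two cores in this assay, a 3.0-fold lower number (0.48 log units; beyond the scatter) from compound 1 to compound 2 and a 2.2-fold higher number (0.35 log units; beyond the scatter) from compound 3 to compound 4, 6.7-fold (0.83 log units) apart, beyond the scatter of two such steps

In this series, the step on one core therefore does not give even the direction of the step on the other. With one pair per core, these data do not show what separates the cores, or whether the same split would appear with other groups at this place.

Open, on these data alone, is how a propyl chain or a longer chain at this place would behave on each core. Also open, as far as these compounds go, is whether the split between the cores persists when a carboxylic acid stands in place of the ethyl ester.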